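The source may report more compounds than this note shows. Statements on the series, on what has been measured and on what is new or still open speak of the compounds shown alone.

Working notes on the series

Compound 1 `Nc1scc(CN2CCN(c3ccc(Cl)cc3Cl)CC2)c1C(=O)c1ccc(Cl)cc1` is tested in a functional assay on CHO cells with adenosine receptor A1 (Homo sapiens) as the target, read by cAMP accumulation and immunoassay, with a stated time of 6 min, tested at 0.01 uM (a higher number here means a weaker effect of the compound at the concentration tested, a lower number a stronger effect), and gives 2%. Compound 2 `Nc1scc(CN2CCN(c3ccccc3C(F)(F)F)CC2)c1C(=O)c1ccc(Cl)cc1` gives 0% in this assay. The two numbers are within the scatter of each other: the step of a number 2 percentage points lower from compound 1 to compound 2 (within the scatter) does not separate compound 1 from compound 2, so on the numbers shown compound 1 sits alongside compound 2 at the low end of the read-out.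

Compound 3 `Nc1scc(CN2CCN(C3CCCCCC3)CC2)c1C(=O)c1ccc(Cl)cc1` is not yet measured. Its change from compound 1 is cycloheptyl in place of 2,4-dichlorophenyl on an amine nitrogen in a ring. Among the compounds with values here, no measured step exchanges an aromatic group for a non-aromatic ring at this position. Within the data shown here, the single step known at the same position, a number 2 percentage points lower from compound 1 to compound 2 (within the scatter), exchanged one aromatic group for another and stayed within the scatter, and it is the only step that bears on the new one. With both measured numbers near zero and that one step flat, no movement beyond the scatter is expected in this assay for compound 3, and the expected step is a number 1 percentage points lower from compound 1 to compound 3 (within the scatter). Compound 3 is therefore estimated to give 1% in this assay, in the range -9% to 11%.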

Compound 3, a percentage reported as activity, at one concentration (the size of the read-out at that concentration, not a potency): 2.9%
Beside the measured number, compound 3's estimate is 1.9 percentage points below it, within the range that was stated.
By their numbers in this assay, from the lowest: compounds 2, 1 and 3 (each within the scatter of the next).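

In this assay, within the data shown here, the step of a number 0.9 percentage points higher from compound 1 to compound 3 (within the scatter) and the step of a number 2.9 percentage points higher from compound 2 to compound 3 (within the scatter) are the first at this position to put a non-aromatic ring in place of an aromatic group, and neither separates the compounds. On an amine nitrogen in a ring, the one seven-membered non-aromatic ring of cycloheptyl therefore gives a read-out that cannot be told from those of 2,4-dichlorophenyl and 2-(trifluoromethyl)phenyl, so among these three compounds an aromatic group at this position makes no visible difference. No measurement at hand offers an explanation for this flat result.

Cycloheptyl and 2,4-dichlorophenyl both count no hydrogen-bond donors, no hydrogen-bond acceptors and no net charge, so it remains open how a group such as a carboxylic acid, a primary amine or a longer chain ending in either would read at this position. On these data alone, the read-out gives the size of the effect at one concentration and not a potency, and whether compound 1, compound 2 and compound 3 would still stay together at other concentrations also remains open.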